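Cyclohexyl in Place of Propyl on the Amine Nitrogen

The source may report more compounds than this note shows. Statements on the series, on what has been measured and on what is new or still open speak of the compounds shown alone.

All four compounds share one core and differ in the group carried on the amine nitrogen. In a functional assay on Caco-2 cells (Homo sapiens) for inhibition, read by MTT assay, with a stated time of 72 h (a lower number here means a stronger inhibitor, a higher number a weaker inhibitor), compound 1, `CCCNC(=C\C(=O)/C=C/c1ccc(O)c(OC)c1)/C=C/c1ccc(O)c(OC)c1`, reaches only the assay's limit of > 25000 nM; this is a limit, not a measured number. Compound 2, `CCC(C)NC(=C\C(=O)/C=C/c1ccc(O)cc1)/C=C/c1ccc(O)cc1`, gives 9400 nM in this assay, while compound 3, `CC(C)CNC(=C\C(=O)/C=C/c1ccc(O)cc1)/C=C/c1ccc(O)cc1`, gives 23000 nM. Among the measured compounds shown here, the one step between compounds differing in a single place is a 2.4-fold higher number from compound 2 to compound 3 (0.39 log units; beyond the scatter), a change on the same amine nitrogen that shifted the number only modestly. Compound 4, `COc1cc(/C=C/C(=O)/C=C(/C=C/c2ccc(O)c(OC)c2)NC2CCCCC2)ccc1O`, has not yet been measured in this assay; it differs from compound 1 by cyclohexyl in place of propyl on an amine nitrogen. For the measured compounds named here, that step cannot be read upward, since compound 1 already sits at the limit (the limit of > 25000 nM in this assay, at which 1 of the 3 values shown sits), and the only measured step on this nitrogen gave no sign that swapping one alkyl group for another moves the number far. The step from the limit is therefore expected to be small, a number no higher from compound 1 to compound 4 (the limit leaves the size open). The estimate for compound 4 is 25000 nM, expected to fall between 8000 nM and 80000 nM.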

Compound 4, half-maximal inhibitory concentration: > 25000 nM
Compound 4 was reported as a limit; the forecaster's own chance of this, stated with the estimate: 55%; the middle value sits exactly at the limit.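

In this assay, among the compounds shown here, compound 1 and compound 4 are both reported only as a limit, so no step between them can be read: the limit of > 25000 nM in this assay, at which 2 of the 4 values shown sit.

The compounds shown leave open how far each of the two lies past that limit, and so whether cyclohexyl in place of propyl changes the number at all.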